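Side-chain change at the high end of the series

This account rests on a few compounds, and the source may have more. Where it says the series, first, only, none or still open, it means among the compounds named here.

In a functional assay on KARPAS-422 cells (Homo sapiens) for antiproliferative activity, read by resazurin assay, with a stated time of 72 h (on this read-out lower numbers stand for stronger inhibition and higher numbers for weaker inhibition), compound 1 `Cc1cc(C)c(CN2CCc3c(Cl)cc(C(CO)c4ccon4)c(Cl)c3C2=O)c(=O)[nH]1` gives 2490 nM; 122 nM (2 entries), compound 2 `Cc1cc(C)c(CN2CCc3c(Cl)cc([C@H](CO)[C@@H]4CCCO4)c(Cl)c3C2=O)c(=O)[nH]1` gives 57 nM and compound 3 `Cc1cc(C)c(CN2CCc3c(Cl)cc([C@@H](CO)[C@@H]4CCOC4)c(Cl)c3C2=O)c(=O)[nH]1` gives 3950 nM. Compound 3 therefore holds the higher of the two single numbers, and compound 1 has no single number to rank.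

Compound 4 `Cc1cc(C)c(CN2CCc3c(Cl)cc([C@H](C)CO)c(Cl)c3C2=O)c(=O)[nH]1` differs from compound 3 by methyl in place of oxolan-3-yl on a saturated chain carbon bound to an aromatic carbon and a saturated chain carbon.

For the measured compounds named here, only one measured step bears on this change: a 69-fold higher number from compound 2 to compound 3 (1.84 log units; beyond the scatter). It exchanges one group bearing a five-membered non-aromatic ring for another, so the read-out can move a long way with the group at this carbon. Going by the values given here, no measured step removes such a ring, which leaves the size of the new step open. Since compound 3 lies so far above compound 2 at 57 nM, a move towards a lower number is expected rather than a further rise.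

The expected change is a 9.9-fold lower number from compound 3 to compound 4 (0.99 log units; beyond the scatter). The range stays wide because the several entries of compound 1 in this assay, 2490 nM; 122 nM (2 entries) lie far apart. For compound 4 the estimated value in this assay is 400 nM, with an expected range of 80 nM to 2000 nM.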

Compound 4, half-maximal inhibitory concentration in the KARPAS-422 assay: 186 nM
Compound 4: middle estimate off by 2.2-fold (0.33 log units), on the high side; the measured number falls inside the stated range.
By their numbers in the KARPAS-422 assay, from the lowest: compound 2; then compound 4; then compound 3.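

In the KARPAS-422 assay, methyl in place of oxolan-3-yl on a saturated chain carbon bound to an aromatic carbon and a saturated chain carbon gives a 21-fold lower number from compound 3 to compound 4 (1.33 log units; beyond the scatter), so a low number at this carbon does not depend on a ring-bearing group. The ring is not without value in the KARPAS-422 assay, however, since compound 2 still lies lower, with a 3.3-fold higher number from compound 2 to compound 4 (0.51 log units; beyond the scatter), and the two ring-bearing compounds fall on opposite sides of the methyl compound 4. In a physicochemical assay for solubility, measured as kinetic solubility (a lower number here means a less soluble compound, a higher number a more soluble compound), compound 3 gives 537000 nM and compound 4 gives 131000 nM as its measured value. The same change from oxolan-3-yl to methyl comes with lower solubility, so better antiproliferative numbers and solubility do not move together in this pair: the measured solubility of compound 3, 537000 nM, and of compound 4, 131000 nM, a 4.1-fold lower number (0.61 log units; beyond the scatter)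

From the compounds shown here alone, whether the whole ring or only its oxygen drives these shifts remains open, and a cyclopentyl group or an aminomethyl group on this saturated chain carbon would separate the two. The standing of the aromatic ring group in compound 1 also remains unsettled, with entries too far apart to place it against compound 2 or compound 4: the several entries of compound 1 in the KARPAS-422 assay, 2490 nM; 122 nM (2 entries)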